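A methyl group added to a weak compound

The source may report more compounds than this note shows. Statements on the series, on what has been measured and on what is new or still open speak of the compounds shown alone.

- Compound 1 `COc1cc(C#N)ccc1OCc1nnc(-c2ccccc2)o1`: 40200 nM.
- Compound 2 `c1ccc(-c2nnc(COc3ccc(-c4nnco4)cc3)o2)cc1`: > 50000 nM, a limit of the assay and not a number.

In a functional assay on MDA-MB-453 cells (Homo sapiens) for cytotoxicity, read by MTT assay, with a stated time of 48 h (on this read-out higher numbers stand for weaker inhibition and lower numbers for stronger inhibition), compound 1 gives 40200 nM, a measured number. Compound 2 reads > 50000 nM in this assay. That reading is only a limit, so compound 2 has no exact position on the scale.

Compound 3 `Cc1ccc(-c2nnc(COc3ccc(-c4nnco4)cc3)o2)cc1` is compound 2 with one small change: methyl in place of hydrogen on an aromatic carbon, turning phenyl into 4-methylphenyl (methyl in place of hydrogen on an aromatic carbon). Among the measured compounds shown here, these data contain no measured pair that differs in one place, so they do not show directly what such a change does. With so little to go on, the expectation is a step no larger than the usual scatter in this assay, with no firm direction. The estimated change is an at least 1.1-fold lower number from compound 2 to compound 3 (0.04 log units; that floor lies within the scatter). A reading that is again only a limit would be no surprise. For the measured compounds named here, the one number available, compound 1 at 40200 nM, also points to weak inhibition. For compound 3, the expected value is 45000 nM, within an estimated range of 15000 nM to 90000 nM.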

Compound 3, half-maximal inhibitory concentration: > 50000 nM
Compound 3 was reported as a limit; the forecaster's own chance of this, stated with the estimate: 55%; middle value at least 1.1-fold (0.04 log units) away from the limit.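

In this assay compound 2 and compound 3 both read only as limits of the assay, so no step can be read between them, because neither has an exact position on the scale: the limit of > 50000 nM in this assay, at which 2 of the 3 values shown sit. The compounds shown leave open whether changing phenyl to 4-methylphenyl alters inhibition at all, and in which direction.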